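A smaller pyrazole group on compound 1

This account rests on a few compounds, and the source may have more. Where it says the series, first, only, none or still open, it means among the compounds named here.

Among the compounds with values here, measured by a physicochemical assay for lipophilicity, using the shake flask method, at pH 7.4 (on this read-out lower numbers stand for lower lipophilicity and higher numbers for higher lipophilicity), compound 1 (`CCCC(Oc1ccc(-n2cc(C(F)(F)F)c(C)n2)cc1)c1ccc(C(=O)NCCC(=O)O)cc1`) gives 2.8 and stands highest of the three compounds measured so far. Compound 2 (`CCCC(Nc1cc(C)c(-n2cc(C(F)(F)F)cn2)c(C)c1)c1ccc(C(=O)NCCC(=O)O)cc1`) lies lower at 2.2 and compound 3 (`CCCC(Nc1ccc(-n2cnc(C(F)(F)F)c2)cc1)c1ccc(C(=O)NCCC(=O)O)cc1`) lies lower still at 1.3 and both gaps to compound 1 go beyond the usual scatter. Each of these two compounds differs from compound 1 in more than one place, so neither gap isolates a single change.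

Compound 4 (`CCCC(Oc1ccc(-n2cc(F)cn2)cc1)c1ccc(C(=O)NCCC(=O)O)cc1`) keeps the core of compound 1 but carries 4-fluoro-1H-pyrazol-1-yl in place of 3-methyl-4-(trifluoromethyl)-1H-pyrazol-1-yl on an aromatic carbon. Within the data shown here, no measured pair shows this swap on its own, so what follows is a judgement. Among the measured compounds shown here, the entering group is the smaller one, and a fall seems likely, probably not past the lowest number so far, held by compound 3 at 1.3 on this scale. The expected step in this assay is a number 0.90 log units lower from compound 1 to compound 4 (beyond the scatter) and would be a fall beyond the scatter. For compound 4 the estimated value is 1.9 with an expected range from 1.4 to 2.3 in this read-out.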

Compound 4, distribution coefficient: 2
The estimate for compound 4 lay 0.10 log units below the measured number; the range from low to high includes it.
By their numbers in this assay, from the lowest: compound 3; then compounds 4 and 2 (each within the scatter of the next); then compound 1.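

Within the data shown here, compound 4 gives the first reading of a change at a single place: on an aromatic carbon para to a large group, putting 4-fluoro-1H-pyrazol-1-yl in place of 3-methyl-4-(trifluoromethyl)-1H-pyrazol-1-yl gives, in this assay, a number 0.80 log units lower from compound 1 to compound 4 (beyond the scatter). The read-out therefore responds to this position, even though both groups are five-membered aromatic rings with 2 hetero atoms, the same hydrogen-bond counts and no net charge; the entering group simply has fewer heavy atoms and fewer fluorines. Nothing measured here accounts for the fall.

The methyl and trifluoromethyl groups leave together, so the compounds shown cannot divide the step between them. Also open, as far as these compounds go, is how the number would respond to a 4-chloro or 4-nitrile group on the same pyrazole.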